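The compounds below may be only part of what the source reports. "The series", "measured", "known", "first", "only" and "open" are said of these compounds alone.

Of the compounds shown here, two that share one core have been measured in an assay on HEK293 cells for displacement of a labelled ligand from growth hormone secretagogue receptor type 1 (Homo sapiens), with a stated time of 60 min; a lower number here means a stronger inhibitor, a higher number a weaker inhibitor. Compound 1 `COc1ccc(-n2cc3nc(-c4cccnc4C)n(C[C@H]4CCCN(C[C@H]5CCCO5)C4)c(=O)c3n2)cc1` gives 52 nM. Compound 2 `COc1cccc(-n2cc3nc(-c4cccnc4C)n(C[C@H]4CCCN(CC5CCCCC5)C4)c(=O)c3n2)c1` gives 200 nM; of the two numbers this is the higher one, and the gap to compound 1 lies beyond the usual scatter, so compound 2 is the weaker inhibitor of the pair. The two structures differ in more than one place, so nothing can be read from them about what any single change contributes.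

Compound 3 `COc1cccc(-n2cc3nc(-c4cccnc4C)n(C[C@H]4CCCN(CC5CCC5)C4)c(=O)c3n2)c1` has not yet been measured. It differs from compound 2 in exactly one place: cyclobutyl in place of cyclohexyl on a saturated chain carbon bound to an amine nitrogen in a ring. Among the compounds with values here, no measured pair shows this change, so there is no measured step to lean on. Both the group that leaves and the group that enters are small rings of carbon only, so a large shift is not expected; a step within the scatter, or only a little beyond it in either direction, seems most likely. Compound 3 is therefore estimated at 250 nM, expected to fall between 80 nM and 800 nM. The step this estimate implies, a 1.3-fold higher number from compound 2 to compound 3 (0.10 log units; within the scatter), is expected to be small.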

Compound 3, half-maximal inhibitory concentration: 1.6 nM
For compound 3 the middle estimate is 160-fold (2.19 log units) above the measured one; the measured number lies below the stated range.
By their numbers in this assay, from the lowest: compound 3; then compound 1; then compound 2.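

In this assay, cyclobutyl in place of cyclohexyl on a saturated chain carbon bound to an amine nitrogen in a ring gives a 130-fold lower number from compound 2 to compound 3 (2.10 log units; beyond the scatter), so the number at this position depends strongly on which carbon ring it carries. The two groups differ only in ring size and carbon count, cyclobutyl holding 4 carbons and cyclohexyl 6, and neither has a hydrogen-bond donor, a hydrogen-bond acceptor or a net charge, so this one pair shows that a change confined to an all-carbon ring can produce a very large step. No measurement at hand says why the step is so large.

This single pair cannot show whether the number follows ring size in a steady way, or whether a cyclopropyl, a cyclopentyl or an open chain such as isobutyl at the same position would behave like cyclobutyl or like cyclohexyl. It also leaves open whether cyclobutyl would give a similar step on the other compound shown, compound 1, which differs from compound 3 in more than one place and so cannot be set directly beside it.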